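A few compounds are considered here, and "the series" means these few. Any claim that something is new, unique, unknown or untested is made for them only; others in the source may bear on it.

Compound 2 `COc1cccc(N2CCNC(=O)N2)c1` gives 47000 nM in an assay on RBL-1 cells for inhibition of Polyunsaturated fatty acid 5-lipoxygenase (Rattus norvegicus) (on this read-out higher numbers stand for weaker inhibition and lower numbers for stronger inhibition), the highest of the two numbers in hand; compound 1 `CCc1cccc(N2CCNC(=O)N2)c1` gives 13000 nM. Among the compounds with values here, the single measured step, a 3.6-fold higher number from compound 1 to compound 2 (0.56 log units; beyond the scatter), concerns a different exchange at the same aromatic carbon and does not cover the change now considered. Compound 3 `CSc1cccc(N2CCNC(=O)N2)c1` differs from compound 2 by methylsulfanyl in place of methoxy on an aromatic carbon. Within the data shown here, no measured step matches this exchange, so the direction is open; the expected step is a 1.6-fold lower number from compound 2 to compound 3 (0.19 log units; within the scatter), a slight downward lean inside a wide band. Compound 3 is therefore estimated at 30000 nM, with a range from 8000 nM to 90000 nM.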

Compound 3, half-maximal inhibitory concentration: 14000 nM
Estimate against measurement, compound 3: 2.1-fold (0.33 log units) above; low and high end bracket the measured number.
By their numbers in this assay, from the lowest: compounds 1 and 3 (each within the scatter of the next); then compound 2.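

At this aromatic carbon, the exchange to methylsulfanyl gives a 3.4-fold lower number from compound 2 to compound 3 (0.53 log units; beyond the scatter) in this assay, so the position responds to this change of a single atom in the group. Within the data shown here, the exchange from ethyl gives a 1.1-fold higher number from compound 1 to compound 3 (0.03 log units; within the scatter), which leaves methoxy as the one group of the three set apart in this read-out. No evidence available here accounts for this difference.

From the compounds shown here alone, whether a chlorine atom, an amine or a longer chain at this carbon would give numbers away from those of compound 1 and compound 3 remains open.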